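Replacing the decyl chain on the triazole-bearing core

A few compounds are considered here, and "the series" means these few. Any claim that something is new, unique, unknown or untested is made for them only; others in the source may bear on it.

Compound 1 `CCCCCCCCCCc1cn(C[C@H](O)[C@H]2OC(=O)C(OCc3ccccc3)=C2OCc2ccccc2)nn1` gives 6750 nM in a functional assay on A549 cells (Homo sapiens) for antiproliferative activity, read by MTT assay, with a stated time of 72 h; a higher number here means a weaker inhibitor, a lower number a stronger inhibitor.
Compound 2 `O=C1O[C@H]([C@@H](O)Cn2cc(C3CC3)nn2)C(OCc2ccccc2)=C1OCc1ccccc1` gives 43900 nM in this assay.
Compound 3 `O=C1O[C@H]([C@@H](O)Cn2cc(-c3cc(F)cc(F)c3)nn2)C(OCc2ccccc2)=C1OCc1ccccc1` gives 41200 nM in this assay.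

Among these three, compound 1 holds the lowest number in this assay, and both of its neighbours lie beyond the scatter from it. Compound 4 `O=C1O[C@H]([C@@H](O)Cn2cc(CNS(=O)(=O)c3ccc(Cl)cc3F)nn2)C(OCc2ccccc2)=C1OCc1ccccc1` shares the core of compound 1 and differs from it in one place: ((4-chloro-2-fluorophenyl)sulfonyl)amino in place of nonyl on a saturated chain carbon bound to an aromatic carbon. The two measured steps that bear on this change both remove the decyl chain from compound 1 and put a small or aromatic group in its stead: a 6.5-fold higher number from compound 1 to compound 2 (0.81 log units; beyond the scatter) and a 6.1-fold higher number from compound 1 to compound 3 (0.79 log units; beyond the scatter). Between those two replacements there is no separation, since a 1.1-fold lower number from compound 2 to compound 3 (0.03 log units; within the scatter). Compound 4 also loses most of the chain, and what enters is an aromatic sulfonamide rather than a plain alkyl, so compound 4 is expected to show a higher number in this assay than compound 1, with an expected step of a 3.7-fold higher number from compound 1 to compound 4 (0.57 log units; beyond the scatter). On that basis the estimate for compound 4 in this assay is 25000 nM, with a likely range from 9000 nM to 60000 nM.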

Compound 4, half-maximal inhibitory concentration: 39100 nM
Compound 4: middle estimate off by 1.6-fold (0.19 log units), on the low side, within the range that was stated.
By their numbers in this assay, from the lowest: compound 1; then compounds 4, 3 and 2 (each within the scatter of the next).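

In this assay, the ((4-chloro-2-fluorophenyl)sulfonyl)amino replacement gives a 5.8-fold higher number from compound 1 to compound 4 (0.76 log units; beyond the scatter), so compound 1 keeps the lowest number of the four, while compounds 4, 3 and 2 each lie within the scatter of the next. For the compounds shown here, compound 4 extends what the earlier compounds showed: it keeps the saturated chain carbon bound to the aromatic carbon, and the group that enters there has more heavy atoms than the nonyl it replaces, along with an aromatic ring, a hydrogen-bond donor and hydrogen-bond acceptors, yet its number stays with those of the cyclopropyl and 3,5-difluorophenyl compounds rather than with compound 1. Nothing given here accounts for why the decyl compound alone stands apart.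

The compounds shown leave open whether the low number of compound 1 depends on chain length, since no shorter alkyl chain such as butyl or hexyl and no longer chain such as dodecyl appears among them. They also leave open how a decyl chain ending in an amine or a carboxylic acid would read, which would show whether the unbroken alkyl chain itself matters at this position.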